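This account rests on a few compounds, and the source may have more. Where it says the series, first, only, none or still open, it means among the compounds named here.

The series rests on a shared core, carried by compound 1 `Cc1c(F)c(N)c2c(=O)cc(-c3ccc(N)c(F)c3)oc2c1F`, compound 2 `Nc1ccc(-c2cc(=O)c3c(N)c(F)c(O)c(F)c3o2)cc1F`, compound 3 `CN(C)CC(=O)OCc1c(F)c(N)c2c(=O)cc(-c3ccc(N)c(F)c3)oc2c1F` and the as yet unmeasured compound 4 `CN(C)CCC(=O)OCc1c(F)c(N)c2c(=O)cc(-c3ccc(N)c(F)c3)oc2c1F`. In a functional assay on MCF7 cells (Homo sapiens) for cytotoxicity, read by neutral red uptake, with a stated time of 3 days (a lower number here means a stronger inhibitor, a higher number a weaker inhibitor), compound 1 gives 13 nM. Compound 3 gives 26 nM in this assay, and the step of a 2.0-fold higher number from compound 1 to compound 3 (0.30 log units; within the scatter) shows the two within the ordinary scatter. Compound 2 stands apart: in this assay it records only a limit, > 10000 nM, at the limit of > 10000 nM in this assay, at which 1 of the 3 values shown sits, so no number is known for it. The step of an at least 760-fold higher number from compound 1 to compound 2 (2.88 log units; beyond the scatter) is large, and the reverse direction, an at least 380-fold lower number from compound 2 to compound 3 (2.58 log units; beyond the scatter), is large as well.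

The change from compound 2 to compound 4 is (((2-(dimethylamino)ethyl)carbonyl)oxy)methyl in place of hydroxy on an aromatic carbon. It follows the same pattern as the step from compound 2 to compound 3, with a chain one carbon longer in the entering ester. The measured step of an at least 380-fold lower number from compound 2 to compound 3 (2.58 log units; beyond the scatter) bears most directly on it, and it points to a large drop in the number. The estimate for compound 4 is therefore expected to lie close to compound 3, as a step of an at least 330-fold lower number from compound 2 to compound 4 (2.52 log units; beyond the scatter). Compound 4 is expected to show 30 nM in this assay, in a range from 10 nM to 100 nM.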

Compound 4, half-maximal inhibitory concentration: 19 nM
The estimate for compound 4 lay 1.6-fold (0.20 log units) above the measured number, and the stated range covers the measured number.
By their numbers in this assay, from the lowest: compounds 1, 4 and 3 (each within the scatter of the next). At a limit, above all of these: compound 2.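

In this assay, the result shows that the entering ester can carry a chain one carbon longer without leaving the scatter: a 1.4-fold lower number from compound 3 to compound 4 (0.14 log units; within the scatter), so (dimethylamino)methyl in place of dimethylamino on the saturated chain carbon bound to the carbonyl carbon does not separate the two esters. The longer ester also stays within the scatter of the unsubstituted methyl group of compound 1, a 1.5-fold higher number from compound 1 to compound 4 (0.16 log units; within the scatter), so this position, ortho to two fluoro groups, has now accepted two ester chains of different length, while the step against hydroxy at the same place, an at least 520-fold lower number from compound 2 to compound 4 (2.72 log units; beyond the scatter), is large as well. Compound 2 remains a limit and not a number, so that step has only a bound on its size: the limit of > 10000 nM in this assay, at which 1 of the 4 values shown sits.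

The compounds shown leave open how a longer chain, or a pyrrolidine or morpholine ring in place of the dimethylamino group, would read in this assay. They also leave open whether an amide in place of the ester, a free hydroxymethyl group or a carboxylic acid at this position would stand with compound 1 or with compound 2.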